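A few compounds are considered here, and "the series" means these few. Any claim that something is new, unique, unknown or untested is made for them only; others in the source may bear on it.

Measured compounds in this series:

Compound 1 `CCC1(CCCCN2CCN(c3cccc(Cl)c3)CC2)C(=O)Nc2ccccc21` gives 0.41 nM in an assay on CHO cells for displacement of a labelled ligand from 5-hydroxytryptamine receptor 7 (Homo sapiens); a higher number here means a weaker inhibitor, a lower number a stronger inhibitor.
Compound 2 `CCC1(CCCCN2CCN(c3ccccc3OC)CC2)C(=O)Nc2ccccc21` gives 5.38 nM in this assay.
Compound 3 `CCC1(CCCCN2CCN(c3cccc(OC)c3)CC2)C(=O)Nc2ccccc21` gives 2.55 nM in this assay.

Compound 3 stands second highest of the three numbers. Its nearest neighbour is compound 2, the step being a 2.1-fold lower number from compound 2 to compound 3 (0.32 log units; beyond the scatter); its furthest is compound 1, the step being a 6.2-fold higher number from compound 1 to compound 3 (0.79 log units; beyond the scatter).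

Compound 4 `CCC1(CCCCN2CCN(c3ccc(Cl)c(Cl)c3)CC2)C(=O)Nc2ccccc21` is the next candidate. The change from compound 3 is 3,4-dichlorophenyl in place of 3-methoxyphenyl on an amine nitrogen in a ring. Within the data shown here, two measured steps bear on it. The step of a 6.2-fold higher number from compound 1 to compound 3 (0.79 log units; beyond the scatter) is the direct counterpart, run backwards: chloro in place of methoxy on the aromatic carbon should recover most of the number seen for compound 1. Among the measured compounds shown here, the step of a 13-fold higher number from compound 1 to compound 2 (1.12 log units; beyond the scatter) shows that the substitution pattern on the phenyl can move the number strongly, so a second chloro on the ring is not a neutral addition; there is no measured pair that tells in which direction it works. The expectation is therefore a clear fall in this assay, of roughly the size of the reversed methoxy step, carrying compound 4 close to compound 1. The expected step is a 4.3-fold lower number from compound 3 to compound 4 (0.63 log units; beyond the scatter). The estimate for compound 4 is 0.6 nM, with a range from 0.15 nM to 2.5 nM.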

Compound 4, inhibition constant: 0.63 nM
For compound 4 the middle estimate is 1.1-fold (0.02 log units) below the measured one; measured number inside the range.
By their numbers in this assay, from the lowest: compounds 1 and 4 (each within the scatter of the next); then compound 3; then compound 2.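

Notes on the aryl group on the amine nitrogen in the ring: a second chloro on the aromatic carbon is the first change in the series that leaves the number in this assay effectively unmoved (a 1.5-fold higher number from compound 1 to compound 4 (0.19 log units; within the scatter)), so this ring accepts 3,4-dichlorophenyl as well as 3-chlorophenyl. The two methoxy compounds now both stand clear of this dichloro compound (a 4.0-fold lower number from compound 3 to compound 4 (0.61 log units; beyond the scatter); an 8.5-fold lower number from compound 2 to compound 4 (0.93 log units; beyond the scatter)), which puts the two chlorinated aryl groups together at the low end of the four compounds, with neither methoxy compound going against that split. No measurement that could explain this split accompanies these numbers.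

Four aryl groups cannot show whether chloro itself matters or whether other groups, such as fluoro, methyl or trifluoromethyl, would give similarly low numbers on this phenyl ring. As far as these compounds go, an unsubstituted phenyl would set the baseline against which the first and second chloro could each be judged, and it also remains open whether the tolerance for the second chloro holds with a shorter chain to the piperazine-type ring.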